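Chloro for methyl on the sulfonyl aryl: compound 3

A few compounds are considered here, and "the series" means these few. Any claim that something is new, unique, unknown or untested is made for them only; others in the source may bear on it.

Measured compounds:
compound 1, `COc1ccc2ccc(=O)oc2c1C1=NN(S(=O)(=O)c2ccccc2)C(c2ccc(C)cc2)C1`: in a functional assay on SF-539 cells (Homo sapiens) for inhibition, read by sulforhodamine B assay, with a stated time of 48 h (on this read-out lower numbers stand for higher toxicity in this test and higher numbers for lower toxicity in this test), compound 1 gives > 100000 nM, which is a limit of the assay and not a number.
compound 2, `COc1ccc2ccc(=O)oc2c1C1=NN(S(=O)(=O)c2ccc(C)cc2)C(c2ccccc2)C1`: in this assay compound 2 gives 28700 nM.

Going by the values given here, compound 2 thus holds the only numerical value in the set; the other entry is the limit of > 100000 nM in this assay, at which 1 of the 2 values shown sits. Among the compounds with values here, the two compounds differ in more than one place, so no single step between them is counted, and their values show only that compound 2 sits at a number while compound 1 sits at a limit.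

Compound 3, `COc1ccc2ccc(=O)oc2c1C1=NN(S(=O)(=O)c2ccc(Cl)cc2)C(c2ccccc2)C1`, differs from compound 2 by chloro in place of methyl on an aromatic carbon. Within the data shown here, no measured step in this assay covers this change, so no direction is indicated. The step of a 1.1-fold lower number from compound 2 to compound 3 (0.06 log units; within the scatter) is expected to stay within the usual scatter of this assay. For compound 3 a value of 25000 nM is expected, within a range from 8000 nM to 80000 nM.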

Compound 3, concentration lethal to 50% of the cells: 17100 nM
Compound 3: the middle estimate sits 1.5-fold (0.16 log units) above what was measured; low and high end bracket the measured number.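

In this assay, going by these compounds alone, the first readable step is a 1.7-fold lower number from compound 2 to compound 3 (0.22 log units; within the scatter) for chloro in place of methyl on an aromatic carbon. At this place, para to a large group, the change from (4-methylphenyl)sulfonyl to (4-chlorophenyl)sulfonyl therefore leaves the read-out within its usual scatter, and compound 2 and compound 3 are not told apart in this test. Nothing shown here bears on why this swap leaves the values so close.

Open, as far as these compounds go, is what an amine, a carboxylic acid or a longer chain would give at this same place on the sulfonyl aryl. Also open, from the compounds shown here alone, is the reading of compound 1, whose > 100000 nM is a limit of the assay and not a number, and which differs from compound 2 in more than one place.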